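Piperidin-1-yl for Dimethylamino on the Shared Core

This account rests on a few compounds, and the source may have more. Where it says the series, first, only, none or still open, it means among the compounds named here.

Of the compounds shown here, two have been measured in an ADME assay on L6 cells (Rattus norvegicus) for cytotoxicity; a lower number here means a stronger inhibitor, a higher number a weaker inhibitor. Among the compounds with values here, compound 2 `CN(C)C12CC(OC(=O)CN3CCC(O)CC3)C(C(c3ccccc3)C1)C(c1ccccc1)C2` gives 102000 nM, the only single number here. Compound 1 `O=C(CN1CCCCC1)OC1CC2(N3CCCCC3)CC(c3ccccc3)C1C(c1ccccc1)C2` gives 60400 nM; > 184000 nM (2 entries). Of the two entries for compound 1, one is a limit of the assay and not a number.

Compound 3 `O=C(CN1CCC(O)CC1)OC1CC2(N3CCCCC3)CC(c3ccccc3)C1C(c1ccccc1)C2` has not yet been measured. It differs from compound 2 in one place: piperidin-1-yl in place of dimethylamino on a saturated ring carbon. Within the data shown here, no measured pair shows this change alone. Compound 1 also bears piperidin-1-yl in that place, but the several entries of compound 1 in this assay, 60400 nM; > 184000 nM (2 entries) fixes no direction. In this assay, no step beyond the scatter is therefore expected. The estimated change is a 1.1-fold lower number from compound 2 to compound 3 (0.05 log units; within the scatter). Compound 3 is expected at about 90000 nM, with an estimated range of 42000 nM to 180000 nM.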

Compound 3, half-maximal inhibitory concentration: > 179000 nM
Compound 3: no number, only a limit; the forecaster's own chance of this, stated with the estimate: 25%; middle value at least 1.9-fold (0.29 log units) away from the limit.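

In this assay compound 3 gives > 179000 nM, which is a limit of the assay and not a number. Within the data shown here, this is the first pair to show piperidin-1-yl in place of dimethylamino on this saturated ring carbon alone, and the change gives an at least 1.7-fold higher number from compound 2 to compound 3 (0.24 log units; that floor lies within the scatter), so the step has a floor but no measured size, and that floor does not separate it from the scatter. The reading of this change is bounded by the assay itself: the limit of > 179000 nM in this assay, at which 1 of the 3 values shown sits.

The compounds shown leave open how large the step really is and whether it goes beyond the scatter. They also leave open whether a pyrrolidin-1-yl or a morpholin-4-yl group on this ring carbon would give a single number in this assay rather than a limit.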